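Amide side chain: the step from compound 3 to compound 4

A few compounds are considered here, and "the series" means these few. Any claim that something is new, unique, unknown or untested is made for them only; others in the source may bear on it.

Measured so far in a functional assay on PC-3 cells (Homo sapiens) for antiproliferative activity, read by MTT assay, with a stated time of 24 h; on this read-out higher numbers stand for weaker inhibition and lower numbers for stronger inhibition
- Compound 1 `CCn1c(C(=O)NCC(=O)OC)ccc1C(CC)(CC)c1ccc(OCS(=O)(=O)c2ccccc2)c(C)c1` gives > 50000 nM (a limit of the assay)
- Compound 2 `CCn1c(C(=O)NCCO)ccc1C(CC)(CC)c1ccc(OCS(=O)(=O)c2ccccc2)c(C)c1` gives 17700 nM
- Compound 3 `CCn1c(C(=O)N[C@H](CO)C(C)C)ccc1C(CC)(CC)c1ccc(OCS(=O)(=O)c2ccccc2)c(C)c1` gives 7300 nM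

Compound 3 holds the lower of the two true numbers. Compound 4 `CCn1c(C(=O)N[C@@H](CO)CCCO)ccc1C(CC)(CC)c1ccc(OCS(=O)(=O)c2ccccc2)c(C)c1` differs from it thus: a group of 7 heavy atoms (5 carbon, 2 oxygen; no ring) in place of a group of 6 heavy atoms (5 carbon, 1 oxygen; no ring), on an amide-type nitrogen with the rest unchanged. The closest guide is a 2.4-fold lower number from compound 2 to compound 3 (0.38 log units; beyond the scatter) on isopropyl in place of hydrogen, and compound 4 no longer carries that isopropyl. Compound 1 gives only a limit, so an at least 2.8-fold lower number from compound 1 to compound 2 (0.45 log units; beyond the scatter) bears less directly. Some of the modest gain may be lost, but no step beyond the scatter is expected in this assay and the estimated step is a 1.6-fold higher number from compound 3 to compound 4 (0.22 log units; within the scatter) with any drift expected towards a higher number. Compound 4 is estimated at 12000 nM with an expected range from 5000 nM to 32000 nM in this series.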

Compound 4, half-maximal inhibitory concentration: 13400 nM
Beside the measured number, compound 4's estimate is 1.1-fold (0.05 log units) below it; measured number inside the range.
By their numbers in this assay, from the lowest: compounds 3, 4 and 2 (each within the scatter of the next, the first and the last beyond it). At a limit, above all of these: compound 1.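

In this assay, 3-hydroxypropyl is accepted on the amide side chain where compound 3 carries isopropyl, with no step beyond the scatter (a 1.8-fold higher number from compound 3 to compound 4 (0.26 log units; within the scatter)). Set against the hydrogen of compound 2, 3-hydroxypropyl also stays within the scatter (a 1.3-fold lower number from compound 2 to compound 4 (0.12 log units; within the scatter)), whereas isopropyl went beyond it (a 2.4-fold lower number from compound 2 to compound 3 (0.38 log units; beyond the scatter)). The remaining step rests on a limit and gives only a bound (an at least 3.7-fold lower number from compound 1 to compound 4 (0.57 log units; beyond the scatter)): the limit of > 50000 nM in this assay, at which 1 of the 4 values shown sits.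

Going by these compounds, whether an amine, a carboxylic acid or a longer chain in this place would move the number stays open. On these data alone, the opposite configuration at the defined stereocentre also stays open.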